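A few compounds are considered here, and "the series" means these few. Any claim that something is new, unique, unknown or untested is made for them only; others in the source may bear on it.

Of the compounds shown here, two have been measured in an assay on isolated protein for inhibition of N-acylethanolamine-hydrolyzing acid amidase (Homo sapiens), read by fluorescence, with a stated time of 90 min; a higher number here means a weaker inhibitor, a lower number a stronger inhibitor. Compound 1 `COc1ncccc1-c1ccc(CO[C@H]2C[C@@H](N=C=S)C2)c(F)c1` gives 304 nM, and compound 2 `COc1ccc(-c2cnc(C(=O)N[C@H]3C[C@@H](N=C=S)C3)cn2)cc1` gives 853 nM. Of the pair, compound 1 carries the lower number, so it is the stronger inhibitor, and the gap between them lies beyond the usual scatter. Among the compounds with values here, the two differ in more than one place, so their values show only that the arrangement in compound 1 is favored, not which part of it matters.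

Compound 3 `Cn1cc(-c2ccc(CO[C@H]3C[C@@H](N=C=S)C3)c(F)c2)cn1` keeps the core of compound 1 and changes a single ring at its end: 1-methyl-1H-pyrazol-4-yl in place of 2-methoxypyridin-3-yl on an aromatic carbon. The rest of the molecule, including the fluoro group and the group of 9 heavy atoms, is unchanged. Within the data shown here, no measured pair shows what such an exchange does here, so the expectation rests on the value of compound 1 alone. Compound 3 is expected to land close to compound 1, with a step from compound 1 to compound 3 of a 1.5-fold higher number from compound 1 to compound 3 (0.17 log units; within the scatter) that may well fall within the scatter. The estimate for compound 3 in this assay is 450 nM, with a likely range from 150 nM to 1500 nM.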

Compound 3, half-maximal inhibitory concentration: 517 nM
For compound 3 the middle estimate is 1.1-fold (0.06 log units) below the measured one; measured number inside the range.
By their numbers in this assay, from the lowest: compounds 1, 3 and 2 (each within the scatter of the next, the first and the last beyond it).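

Compared with the first two compounds, this pair changes only one place, so it isolates the effect of the ring at this position: replacing 2-methoxypyridin-3-yl with 1-methyl-1H-pyrazol-4-yl gives a 1.7-fold higher number from compound 1 to compound 3 (0.23 log units; within the scatter) in this assay, and the two rings cannot be told apart by these numbers. At this aromatic carbon, para to a group of 9 heavy atoms and meta to a fluoro group, a five-membered aromatic ring of 6 heavy atoms therefore serves as well as a six-membered aromatic ring of 8 heavy atoms, at least for these two rings, which both count 0 hydrogen-bond donors and 2 hydrogen-bond acceptors. No supporting measurement is available to explain why the exchange leaves the value within the scatter.

The compounds shown leave open whether this position needs an aromatic ring at all, since a plain methyl group, an amine or a carboxylic acid on the same carbon would test that directly. They also leave open whether the methoxy group of 2-methoxypyridin-3-yl or the methyl group of 1-methyl-1H-pyrazol-4-yl matters, which the parent pyridin-3-yl and 1H-pyrazol-4-yl rings could help to settle.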